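Oxygen substituent change from compound 2 to compound 3

This account rests on a few compounds, and the source may have more. Where it says the series, first, only, none or still open, it means among the compounds named here.

In an ADME assay on L02 cells (Homo sapiens) for cytotoxicity, read by MTT assay, with a stated time of 48 h (on this read-out lower numbers stand for stronger inhibition and higher numbers for weaker inhibition), compound 1 (`CCn1c(C(=O)N(CCC#N)CCC#N)ccc1C(CC)(CC)c1ccc(OCC(O)C(C)(C)C)c(C)c1`) gives 1700 nM, and compound 2 (`C#CC(C)OC(=O)c1ccc(C(CC)(CC)c2ccc(OCC(O)C(C)(C)C)c(C)c2)n1CC`) stands highest of the two at 23700 nM. Compound 3 (`CCn1c(C(=O)Oc2ccc(CCO)cc2)ccc1C(CC)(CC)c1ccc(OCC(O)C(C)(C)C)c(C)c1`) carries 4-(2-hydroxyethyl)phenyl in place of 1-methylprop-2-yn-1-yl on an oxygen next to a carbonyl group. Going by the values given here, only one measured step bears on this, a 14-fold higher number from compound 1 to compound 2 (1.14 log units; beyond the scatter), a large change at the same carbonyl carbon, and it shows sensitivity there but gives no direction for this swap. A moderate move toward lower numbers is expected, a 2.4-fold lower number from compound 2 to compound 3 (0.37 log units; beyond the scatter), with low confidence. For compound 3 the estimated value is 10000 nM, with an expected range of 2500 nM to 40000 nM.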

Compound 3, half-maximal inhibitory concentration: 22700 nM
Beside the measured number, compound 3's estimate is 2.3-fold (0.36 log units) below it, and the stated range covers the measured number.
By their numbers in this assay, from the lowest: compound 1; then compounds 3 and 2 (each within the scatter of the next).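

In this assay, 4-(2-hydroxyethyl)phenyl in place of 1-methylprop-2-yn-1-yl on an oxygen next to a carbonyl group makes no difference beyond the scatter (a 1.0-fold lower number from compound 2 to compound 3 (0.02 log units; within the scatter)). The step to compound 3 from the nitrogen-linked group of compound 1 is large (a 13-fold higher number from compound 1 to compound 3 (1.13 log units; beyond the scatter)), so compounds 2 and 3 both stand well above compound 1. No measurement shown accounts for this gap. Open, going by these compounds, is whether the gap follows the nitrogen on the carbonyl carbon or the nitrile chains of compound 1. A plain dimethylamine amide or a carboxylic acid at this carbonyl carbon would help separate these.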